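From 2-methoxyphenyl to 4-methoxyphenyl in a cell toxicity test

This account rests on a few compounds, and the source may have more. Where it says the series, first, only, none or still open, it means among the compounds named here.

Of the compounds shown here, two have so far been measured in an ADME assay on THP-1 cells (Homo sapiens) for cytotoxicity, read by flow cytometry and propidium iodide staining, with a stated time of 72 h; a lower number here means a stronger inhibitor, a higher number a weaker inhibitor. Here compound 1 `COc1cccc(-c2cc(=O)c3cc(NC(C)=O)ccc3o2)c1` gives 10000 nM. Compound 2 `COc1ccccc1-c1oc2ccc(NC(C)=O)cc2c(=O)c1O` gives > 125000 nM, which is a limit of the assay and not a number. Compound 3 `COc1ccc(-c2oc3ccc(NC(C)=O)cc3c(=O)c2O)cc1` has yet to be measured. It differs from compound 2 in one place 4-methoxyphenyl in place of 2-methoxyphenyl on an aromatic carbon: 4-methoxyphenyl stands in place of 2-methoxyphenyl, on an aromatic carbon next to the ring oxygen, and the atoms are the same but joined differently. For the measured compounds named here, no measured pair shows what such a change does, so any forecast is uncertain. With compound 2 at > 125000 nM, a number for compound 3 could only lie towards stronger inhibition, and compound 1 at 10000 nM suggests how far that might go. The expected change is modest, and the estimated step is an at least 1.3-fold lower number from compound 2 to compound 3 (0.14 log units; that floor lies within the scatter). For compound 3 the expected value is 90000 nM, with an estimated range from 20000 nM to 125000 nM.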

Compound 3, half-maximal inhibitory concentration: 9000 nM
For compound 3 the middle estimate is 10-fold (1.00 log units) above the measured one, outside the stated range (below it).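

In this assay, exchanging 2-methoxyphenyl for 4-methoxyphenyl gives an at least 13-fold lower number from compound 2 to compound 3 (1.14 log units; beyond the scatter). The two groups hold the same atoms, so this pair shows that, on this aromatic carbon next to the ring oxygen, the place of the methoxy group on the phenyl ring alone can shift the reading by much more than the usual scatter. The true size of the step remains unknown, because compound 2 gives a limit of the assay and not a number: the limit of > 125000 nM in this assay, at which 1 of the 3 values shown sits.

As far as these compounds go, it remains open whether an amine or a carboxylic acid in place of the methoxy group on that phenyl ring would give a number close to that of compound 3 at 9000 nM. Compound 1 differs from compound 3 in more than one place, and no pair shown isolates the effect of the hydroxy group on the core.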